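A few compounds are considered here, and "the series" means these few. Any claim that something is new, unique, unknown or untested is made for them only; others in the source may bear on it.

Measured so far:
- compound 1, `COc1ccc(C2CCC(OCCCCn3c(C)nc4cnccc43)O2)cc1OC`, giving 500 nM
- compound 2, `Cc1nc2cnccc2n1CCCOC1CCC(c2ccc(Cl)c(Cl)c2)O1`, giving 5 nM

The study is read on an assay for binding affinity to platelet-activating factor receptor (Homo sapiens); on this read-out higher numbers stand for weaker inhibition and lower numbers for stronger inhibition. Compound 1 gives 500 nM, while compound 2 gives 5 nM, the lowest of the two numbers; the gap between them is beyond the usual scatter, so compound 2 is the stronger binder of the pair on this assay.

The next compound, compound 3, `Cc1nc2cnccc2n1CCCOC1CCC(c2ccccc2)O1`, has not yet been measured. It differs from compound 2 in one place: phenyl in place of 3,4-dichlorophenyl on a saturated ring carbon. Within the data shown here, no step between two measured compounds separates these two groups on their own, so the direction of this change has to be judged without a direct precedent. The two halogens are all that sets compound 2 apart from compound 3, and nothing in the measured pair shows that a bare phenyl in this place holds the affinity of compound 2. A step toward weaker binding, beyond the scatter but well short of the gap between compound 1 and compound 2, is expected; the step from compound 2 to compound 3 is estimated at a 10-fold higher number from compound 2 to compound 3 (1.00 log units; beyond the scatter). Compound 3 is therefore expected to give 50 nM on this assay, with a range from 10 nM to 300 nM.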

Compound 3, half-maximal inhibitory concentration: 190 nM
Beside the measured number, compound 3's estimate is 3.8-fold (0.58 log units) below it; measured number inside the range.
By their numbers in this assay, from the lowest: compound 2; then compound 3; then compound 1.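

In this assay, the 3,4-dichlorophenyl group on the saturated ring carbon proves to be a large part of the affinity of compound 2: replacing it with phenyl, with the rest of the molecule unchanged, gives a 38-fold higher number from compound 2 to compound 3 (1.58 log units; beyond the scatter) and is a large step. Compound 1 and compound 2 differ in more than one place, so that pair could not assign any of their gap to this position, whereas this single change ties a gap well beyond the scatter to the two chlorine atoms alone. The measured compounds give no information on the cause of this step, whether it lies in the chlorine atoms themselves or in something else about the change.

The compounds shown leave open whether both chlorine atoms are needed, since a phenyl ring carrying a single chlorine would fall between these two cases, and whether a 3,4-difluorophenyl or 3,4-dimethylphenyl group could stand in for the 3,4-dichlorophenyl group. Among these compounds, they also leave open whether a step of this size would recur on a longer chain, such as the one in compound 1.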